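This account rests on a few compounds, and the source may have more. Where it says the series, first, only, none or still open, it means among the compounds named here.

Measured so far: compound 1 `COc1cc(N2C(N)=C(C#N)C(c3c(OC)ccc4ccccc34)C3=C2CC(C)(C)CC3=O)cc(OC)c1OC` gives "not active" (no number reported) in a functional assay on Ehrlich cells (Mus musculus) for cytotoxicity; on this read-out higher numbers stand for weaker inhibition and lower numbers for stronger inhibition; compound 2 `COc1cc(N2C(N)=C(C#N)C(c3ccc(Cl)cc3Cl)C3=C2CC(C)(C)CC3=O)cc(OC)c1OC` gives 94700 nM; compound 3 `COc1cc(N2C(N)=C(C#N)C(c3cccc([N+](=O)[O-])c3)C3=C2CC(C)(C)CC3=O)cc(OC)c1OC` gives "not active" (no number reported).

Compound 1 carries a 2-methoxynaphthalen-1-yl group on the saturated ring carbon of its shared core. In this assay compound 1 returns no number at all, and the same holds for compound 3, so no ranking of compound 1 against either of these two can be drawn. Only compound 2 is tied to an actual concentration in this assay, and that concentration is very high, which means only weak inhibition.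

Compound 4 `COc1cc(N2C(N)=C(C#N)C(c3ccccc3)C3=C2CC(C)(C)CC3=O)cc(OC)c1OC` changes one place on the core of compound 1: phenyl in place of 2-methoxynaphthalen-1-yl on a saturated ring carbon. Since compound 1 itself has no number, the size of the step cannot be read from the data, and no comparison between two measured compounds in this set carries a step either. The expectation therefore leans on the weak picture that compounds 1, 2 and 3 give together in this assay: any number for compound 4 is expected to stay in the weak range, with a real chance that again no number is reported.

Compound 4 is estimated at 100000 nM in this assay, within a range from 30000 nM to 300000 nM.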

Compound 4, half-maximal inhibitory concentration: "not active" (no number reported)
Nothing numeric was reported for compound 4; the estimate stays without a comparison.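

In this assay neither compound 1 nor compound 4 comes with a number, so no step can be read between them. No other information here accounts for this result. Left open is whether phenyl in place of 2-methoxynaphthalen-1-yl changes inhibition at all, and how compound 1, compound 3 and compound 4 rank against compound 2.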